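Lipophilicity notes: chloro and methyl additions on a thiourea series

The source may hold more compounds than are shown below. What is called first, only, known or untested is meant among the compounds shown, and "the series" means these compounds.

Measured in a physicochemical assay for lipophilicity, in phosphate buffer, measured as octanol-water partition; on this read-out higher numbers stand for higher lipophilicity and lower numbers for lower lipophilicity:
compound 1 `O=C(NC(=S)Nc1ccccc1)Nc1ccc2c(c1)C(=O)C(=O)N2Cc1ccccc1`: 2.48
compound 2 `O=C(NC(=S)Nc1ccccc1Cl)Nc1ccc2c(c1)C(=O)C(=O)N2Cc1ccccc1`: 3.01
compound 3 `O=C(NC(=S)Nc1ccccc1)Nc1ccc2c(c1)C(=O)C(=O)N2Cc1ccccc1Cl`: 3.18

Compound 3 stands beyond the scatter above compound 1 and within the scatter of compound 2, so compounds 2 and 3 cannot be ordered on these numbers. The change now followed leads from compound 3 to compound 4 `Cc1ccccc1NC(=S)NC(=O)Nc1ccc2c(c1)C(=O)C(=O)N2Cc1ccccc1Cl`: methyl in place of hydrogen on an aromatic carbon. It falls on the same ring that carried the chloro in compound 2.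

Among the compounds with values here, two measured steps bear on it, both additions of a single halogen to an aromatic carbon: a number 0.53 log units higher from compound 1 to compound 2 (beyond the scatter) and a number 0.70 log units higher from compound 1 to compound 3 (beyond the scatter). Both ran upward and both cleared the scatter. Methyl is one carbon rather than a chlorine, but as an addition of one heavy atom without donors or acceptors it is expected to move this assay in the same direction and on a comparable scale, perhaps a little less than the chloro steps. The expected step is therefore a number 0.47 log units higher from compound 3 to compound 4 (beyond the scatter). On that basis compound 4 is estimated at 3.65, with a range from 3.3 to 4. Three compounds give a narrow base; the upper end of the range allows for a methyl step as large as the chloro steps.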

Compound 4, partition coefficient: 3.7
For compound 4 the middle estimate is 0.05 log units below the measured one; the measured number falls inside the stated range.
By their numbers in this assay, from the lowest: compound 1; then compounds 2 and 3 (each within the scatter of the next); then compound 4.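

Within the data shown here, the methyl change gives a number 0.52 log units higher from compound 3 to compound 4 (beyond the scatter) in this assay and is the first step that adds a carbon rather than a halogen, so an upward step beyond the scatter is no longer tied to chloro alone. It is also the first step taken from a compound that already carries a chloro: the benzyl chloro of compound 3 does not stop a further addition on the anilino ring, at a carbon ortho to a large group, from clearing the scatter. No measurement at hand accounts for the size of this step.

On these data alone, whether phenyl to 2-methylphenyl gives a similar step on compound 1, without the benzyl chloro, remains open, as does how far this step depends on the place of the methyl on that ring. Also open, as far as these compounds go, is whether a larger or more polar replacement at the same carbon, such as an ethyl chain, an amine or a carboxylic acid, would continue the upward run or reverse it in this assay on this core.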